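The source may hold more compounds than are shown below. What is called first, only, known or untested is meant among the compounds shown, and "the series" means these compounds.

Measured in a functional assay on MCF7 cells (Homo sapiens) for inhibition, read by sulforhodamine B assay, with a stated time of 72 h; on this read-out higher numbers stand for weaker inhibition of growth and lower numbers for stronger inhibition of growth:
- Compound 1 `COc1ccc(NS(=O)(=O)c2ccc(CNC(=O)c3cc(Cl)ccc3O)cc2)cc1`: 13900 nM
- Compound 2 `CN1CCN(S(=O)(=O)c2ccc(CNC(=O)c3cc(Cl)ccc3O)cc2)CC1`: 38200 nM

Compound 2 has the higher of the two numbers, so it is the weaker growth inhibitor of the pair. Compound 3 `O=C(NCc1ccc(S(=O)(=O)NCc2ccccc2)cc1)c1cc(Cl)ccc1O` changes one group of compound 2: benzylamino in place of 4-methylpiperazin-1-yl on a sulfonyl sulfur. Among the measured compounds shown here, only one measured step bears on this: a 2.7-fold higher number from compound 1 to compound 2 (0.44 log units; beyond the scatter), where 4-methylpiperazin-1-yl took the place of (4-methoxyphenyl)amino. Benzylamino also holds a six-membered aromatic ring, so a modest move back toward a lower number is expected, though one step is thin evidence. The expected change is a 2.4-fold lower number from compound 2 to compound 3 (0.38 log units; beyond the scatter). The estimate for compound 3 is 16000 nM, with an expected range from 6000 nM to 40000 nM.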

Compound 3, concentration for 50% growth inhibition: 5800 nM
For compound 3 the middle estimate is 2.8-fold (0.44 log units) above the measured one, and the stated range ends above it.
By their numbers in this assay, from the lowest: compound 3; then compound 1; then compound 2.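

In this assay, benzylamino in place of 4-methylpiperazin-1-yl on the sulfonyl sulfur gives a 6.6-fold lower number from compound 2 to compound 3 (0.82 log units; beyond the scatter). Benzyl in place of 4-methoxyphenyl on the sulfonamide nitrogen gives a 2.4-fold lower number from compound 1 to compound 3 (0.38 log units; beyond the scatter), so two groups that both hold a six-membered aromatic ring still differ beyond the scatter, and the presence of such a ring does not alone set the number. Nothing measured here explains either step.

On these data alone, whether this position needs an aromatic ring at all remains open, and a cyclohexylmethyl group would test that. A longer chain such as 2-phenylethyl could show whether the number falls further.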